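Removing a benzyl fluorine from a compound with a low inhibition number in this assay

The source may hold more compounds than are shown below. What is called first, only, known or untested is meant among the compounds shown, and "the series" means these compounds.

Measured compounds:
- compound 1, `CN(C)CCCCCSC1=Nc2ccccc2C(CC(=O)NCc2ccccc2)N1c1ccc(-c2ccc(F)cc2)cc1`: 97.6%
- compound 2, `CN(C)CCCCCSC1=Nc2ccccc2C(CC(=O)NCc2ccc(F)cc2)N1c1ccccc1`: 26.7%

In an assay on cells for inhibition of Voltage-dependent T-type calcium channel subunit alpha-1G (Homo sapiens), read by patch clamp, tested at 10 uM (on this read-out lower numbers stand for less inhibition and higher numbers for more inhibition at the one concentration tested (going by the name of the read-out)), compound 2 gives 26.7%, the lowest of the two numbers, while compound 1 gives 97.6%, a gap well beyond the scatter. Compound 3, `CN(C)CCCCCSC1=Nc2ccccc2C(CC(=O)NCc2ccccc2)N1c1ccccc1`, has not been measured. It differs from compound 2 by hydrogen in place of fluoro on an aromatic carbon, a 4-fluorobenzyl becoming a benzyl. For so small a change the step of a number 1.3 percentage points higher from compound 2 to compound 3 (within the scatter) is expected to stay within the scatter, with no clear direction. Compound 3 is therefore estimated at 28%, ranging from 8% to 50%.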

Compound 3, a percentage reported as inhibition, at one concentration (the size of the read-out at that concentration, not a potency): 46.5%
The estimate for compound 3 lay 18.5 percentage points below the measured number; measured number inside the range.
By their numbers in this assay, from the lowest: compound 2; then compound 3; then compound 1.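

Replacing the fluoro with hydrogen on the benzyl ring gives a number 19.8 percentage points higher from compound 2 to compound 3 (beyond the scatter), so even this single-atom change at this position can move the number past the usual scatter. Hydrogen in place of 4-fluorophenyl, at a different place on the molecule, gives a number 51.1 percentage points lower from compound 1 to compound 3 (beyond the scatter), a step of larger size. Nothing measured here explains either step. As far as these compounds go, it remains open whether a chlorine, methoxy or nitrile on that aromatic carbon would read closer to the fluoro or to the hydrogen.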